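This account rests on a few compounds, and the source may have more. Where it says the series, first, only, none or still open, it means among the compounds named here.

Working notes on the series. Within the data shown here, all three compounds measured so far share one core; in an assay for inhibition of Tryptophan 2,3-dioxygenase (Homo sapiens), with a stated time of 1 h, tested at 10 uM (on this read-out lower numbers stand for less inhibition and higher numbers for more inhibition at the one concentration tested (going by the name of the read-out)), compound 1 `CC(=O)Nc1ccc(CNc2cc(Br)cc3[nH]ncc23)cc1` is reported as "not active" (no number reported) and compound 2 `Nc1cccc(CNc2cc(Br)cc3[nH]ncc23)c1` as "not active" (no number reported), each without a number. Among the measured compounds shown here, compound 3 `FC(F)(F)c1cccc(CNc2cc(Br)cc3[nH]ncc23)c1` is the only member with a figure: in this assay compound 3 gives 56%, so it stands alone at the top of what is known, with nothing to rank it against beyond two entries that carry no number at all.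

Compound 4 `O=C1CCCC(Nc2cccc(CNc3cc(Br)cc4[nH]ncc34)c2)C1` is not yet measured. It differs from compound 3 in one place: (3-oxocyclohexyl)amino in place of trifluoromethyl on an aromatic carbon. The trifluoromethyl group of compound 3 is gone and a (3-oxocyclohexyl)amino group sits on the aromatic carbon meta to a large group. For the measured compounds named here, no step between measured compounds exists, so the size of this change is open. The two entries without a number, compound 1 and compound 2, suggest that substituents of this kind on that ring need not keep inhibition, and a step down from compound 3 is expected, beyond the scatter, in this assay: the expected step is a number 31 percentage points lower from compound 3 to compound 4 (beyond the scatter). Compound 4 is estimated at 25%, within 0% to 50%.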

Compound 4, a percentage reported as inhibition, at one concentration (the size of the read-out at that concentration, not a potency): 46%
Estimate against measurement, compound 4: 21 percentage points below; measured number inside the range.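

In this assay the exchange of trifluoromethyl for (3-oxocyclohexyl)amino on this aromatic carbon gives a number 10 percentage points lower from compound 3 to compound 4 (within the scatter) and so shows that this position keeps measurable inhibition with a much larger group carrying a six-membered non-aromatic ring, a hydrogen-bond donor and hydrogen-bond acceptors. A nitrogen on this carbon does not settle the read-out by itself, since compound 2, with a plain amino group, is reported as "not active" (no number reported) while compound 4 gives 46% in the same assay. The data at hand offer no explanation for this result.

Going by these compounds, whether the carbonyl of the cyclohexyl ring matters remains open, as does the outcome with a plain cyclohexylamino group, a morpholine or a carboxylic acid on this aromatic carbon. Two numbers within the scatter of each other do not yet allow any ranking of substituents at this position.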